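This account rests on a few compounds, and the source may have more. Where it says the series, first, only, none or still open, it means among the compounds named here.

Measured so far in a functional assay on PC-3 cells (Homo sapiens) for antiproliferative activity, read by MTT assay, tested at 5 uM; on this read-out higher numbers stand for a stronger effect at the one concentration tested and lower numbers for a weaker effect:
- compound 1 `COc1cc(C2=NN(C(C)=O)C(c3cc(Cl)cc(Cl)c3)O2)cc(OC)c1OC`, 93.9%
- compound 2 `COc1ccc(OC)c(C2OC(c3cc(OC)c(OC)c(OC)c3)=NN2C(C)=O)c1`, 43.2%
- compound 3 `COc1cc(C(=O)N/N=C/c2ccc(F)cc2)cc(OC)c1OC`, 82.8%

Compound 2 stands lowest of the three; compound 3 sits nearer to it and compound 1 furthest, both beyond the scatter. Compound 4 `COc1cc(C2=NN(C(C)=O)C(c3ccccc3F)O2)cc(OC)c1OC` is not yet measured. It differs from compound 2 in one place: 2-fluorophenyl in place of 2,5-dimethoxyphenyl on a saturated ring carbon. Going by the values given here, the only measured step at this position is a number 50.7 percentage points lower from compound 1 to compound 2 (beyond the scatter), where a halogenated phenyl at the saturated ring carbon went with the much higher number. Compound 3, which carries a fluorophenyl on another core, also shows a high value. On that basis a step upward from compound 2 to compound 4 is expected, beyond the scatter: a number 31.8 percentage points higher from compound 2 to compound 4 (beyond the scatter). Compound 4 is therefore estimated at 75%, expected to fall between 52% and 92%.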

Compound 4, a percentage reported as inhibition, at one concentration (the size of the read-out at that concentration, not a potency): 31.6%
The estimate for compound 4 lay 43.4 percentage points above the measured number, and the stated range ends above it.
By their numbers in this assay, from the lowest: compound 4; then compound 2; then compound 3; then compound 1.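

In this assay, a halogen on the phenyl at the saturated ring carbon does not by itself go with a high number: 2-fluorophenyl in place of 2,5-dimethoxyphenyl gives a number 11.6 percentage points lower from compound 2 to compound 4 (beyond the scatter), and in place of 3,5-dichlorophenyl it gives a number 62.3 percentage points lower from compound 1 to compound 4 (beyond the scatter). The number at this position therefore depends on more than the presence of a halogen, with compound 4 the lowest of the compounds sharing this core. No evidence on hand accounts for these steps.

Open, on these data alone, is whether a 2-chlorophenyl or 3,5-difluorophenyl would separate halogen identity from ring placement. Also open, as far as these compounds go, is how a phenyl carrying an amine or a carboxylic acid would fare at this position.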